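Compound 3 and the step to its 4-methoxyphenyl analogue

The source may hold more compounds than are shown below. What is called first, only, known or untested is meant among the compounds shown, and "the series" means these compounds.

Compound 1 `CCOC(=O)C1=C(C[Se]C(=O)c2ccc(C)cc2)NC(=O)NC1c1cccc([N+](=O)[O-])c1`: 24500 nM
Compound 2 `CCOC(=O)C1=C(C[Se]C(=O)c2ccc(C)cc2)NC(=O)NC1c1ccc(N(C)C)cc1`: 29600 nM
Compound 3 `CCOC(=O)C1=C(C[Se]C(=O)c2ccc(C)cc2)NC(=O)NC1c1ccc(O)c(OC)c1`: 8100 nM

These three compounds share one core and differ in the aryl group, and they were compared in a physicochemical assay, read by spectrophotometry, with a stated time of 10 min; a higher number here means that more compound is needed for the effect, a lower number that less compound is needed. Compound 3 gives the lowest number of the three, and its steps to both others lie beyond the scatter. Compound 4 `CCOC(=O)C1=C(C[Se]C(=O)c2ccc(C)cc2)NC(=O)NC1c1ccc(OC)cc1` has not yet been measured. Its change from compound 3 is 4-methoxyphenyl in place of 4-hydroxy-3-methoxyphenyl on a saturated ring carbon.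

Within the data shown here, no measured compound carries this new group, so the evidence is indirect. The closest guides are a 3.0-fold lower number from compound 1 to compound 3 (0.48 log units; beyond the scatter) and a 3.7-fold lower number from compound 2 to compound 3 (0.56 log units; beyond the scatter), both modest, where the 4-hydroxy-3-methoxyphenyl group enters. Leaving it may therefore undo part of that gain. The groups of the other two compounds, which differ widely, give a 1.2-fold higher number from compound 1 to compound 2 (0.08 log units; within the scatter), within the scatter. The expected step is a 2.3-fold higher number from compound 3 to compound 4 (0.37 log units; beyond the scatter), towards a higher number. For compound 4 the estimated value is 19000 nM, with an expected range from 9000 nM to 36000 nM.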

Compound 4, half-maximal effective concentration: 22500 nM
Beside the measured number, compound 4's estimate is 1.2-fold (0.07 log units) below it, and the stated range covers the measured number.
By their numbers in this assay, from the lowest: compound 3; then compounds 4, 1 and 2 (each within the scatter of the next).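

In this assay, the step to 4-methoxyphenyl from 4-hydroxy-3-methoxyphenyl is a 2.8-fold higher number from compound 3 to compound 4 (0.44 log units; beyond the scatter), so a methoxy group on the phenyl ring does not by itself keep the low number of compound 3. Compound 4 instead stands level with the other two, with a 1.3-fold lower number from compound 2 to compound 4 (0.12 log units; within the scatter) and a 1.1-fold lower number from compound 1 to compound 4 (0.04 log units; within the scatter). Among the four compounds, 4-methoxyphenyl, 3-nitrophenyl and 4-(dimethylamino)phenyl are not told apart at this saturated ring carbon, and only 4-hydroxy-3-methoxyphenyl stands apart; no measurement shown accounts for this.

The step loses the hydroxy group and also changes how the methoxy group is placed, so the compounds shown do not separate these two changes. From the compounds shown here alone, a phenyl group carrying hydroxy as its only substituent would be needed to do so, and an amine or a carboxylic acid in that group's place remains untested here.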